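A Methylcarbamoyl Swap on the Side Chain of Compound 1

A few compounds are considered here, and "the series" means these few. Any claim that something is new, unique, unknown or untested is made for them only; others in the source may bear on it.

compound 1 `Cn1ncc(Cl)c1-c1cc(C(=O)N[C@@H]2CN[C@H](CC(O)CO)C[C@H]2c2ccc(F)c(F)c2)oc1Cl` gives 800 nM
compound 2 `Cn1ncc(Cl)c1-c1cc(C(=O)N[C@@H]2CN[C@H](CC(O)CO)C[C@H]2c2ccc(Cl)c(Cl)c2)oc1Cl` gives 1110 nM
compound 3 `Cn1ncc(Cl)c1-c1cc(C(=O)N[C@@H]2CN[C@H](CCN3CCCCC3)C[C@H]2c2ccc(Cl)c(Cl)c2)oc1Cl` gives 1020 nM

All three values come from a functional assay on HCT-116 cells (Homo sapiens) for antiproliferative activity, read by sulforhodamine B assay, with a stated time of 72 h (a higher number here means a weaker inhibitor, a lower number a stronger inhibitor), and lie within the scatter of one another, so compound 1, at 800 nM, is not separated from the other two. Compound 4 `CNC(=O)C[C@@H]1C[C@@H](c2ccc(F)c(F)c2)[C@H](NC(=O)c2cc(-c3c(Cl)cnn3C)c(Cl)o2)CN1` has not yet been measured and differs from compound 1 in one place: methylcarbamoyl in place of 1,2-dihydroxyethyl on a saturated chain carbon bound to a saturated ring carbon.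

Among the compounds with values here, one measured step touches this place: a 1.1-fold lower number from compound 2 to compound 3 (0.04 log units; within the scatter), with (piperidin-1-yl)methyl in place of 1,2-dihydroxyethyl. The other step, a 1.4-fold higher number from compound 1 to compound 2 (0.14 log units; within the scatter), lies elsewhere in the molecule. Both stayed within the scatter. Within the data shown here, no measured compound carries methylcarbamoyl, so the evidence is thin, but no step beyond the scatter is expected in this assay. The estimated 1.1-fold higher number from compound 1 to compound 4 (0.05 log units; within the scatter) reflects that expectation. For compound 4 the expected value is 900 nM, with an estimated range from 400 nM to 2000 nM.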

Compound 4, half-maximal inhibitory concentration: 1100 nM
Estimate against measurement, compound 4: 1.2-fold (0.09 log units) below; low and high end bracket the measured number.
By their numbers in this assay, from the lowest: compounds 1, 3, 4 and 2 (each within the scatter of the next).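

In this assay, methylcarbamoyl at this place on the saturated chain carbon gives a 1.4-fold higher number from compound 1 to compound 4 (0.14 log units; within the scatter), so a second, quite different replacement of 1,2-dihydroxyethyl also stays within the scatter. The earlier evidence at this place was only a 1.1-fold lower number from compound 2 to compound 3 (0.04 log units; within the scatter), a change made with 3,4-dichlorophenyl on the saturated ring carbon; the new step extends the same reading to a compound carrying 3,4-difluorophenyl and to a group with a carbonyl. No measurement among these compounds accounts for why the number holds across this change.

From the compounds shown here alone, it remains open whether a carboxylic acid, a primary amine or a longer chain at this place would give a step beyond the scatter. Going by these compounds, it also remains open how methylcarbamoyl would read alongside 3,4-dichlorophenyl.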